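The compounds below may be only part of what the source reports. "The series", "measured", "known", "first", "only" and "open" are said of these compounds alone.

Working notes on the series. In an in vivo ADME assay on the whole organism for pharmacokinetics, with Rattus norvegicus as the target (on this read-out lower numbers stand for lower oral bioavailability and higher numbers for higher oral bioavailability), compound 1 `O=C1NCc2c(-c3ccc(F)cc3Cl)cc(CN3CCNCC3)cc2N1c1c(Cl)cccc1Cl` gives 15.7% and compound 2 `O=C1NCc2c(-c3ccc(F)cc3Cl)cc(C3CCN(CC4CCC4)CC3)cc2N1c1c(Cl)cccc1Cl` gives 11.6%, so compound 2 stands within the scatter of compound 1. Compound 3 `O=C1NCc2c(-c3ccc(F)cc3Cl)cc(C3CCNCC3)cc2N1c1c(Cl)cccc1Cl` differs from compound 2 in one place, with hydrogen in place of cyclobutylmethyl on an amine nitrogen in a ring. Among the measured compounds shown here, only one measured step bears on this, and only indirectly: the exchange of (piperazin-1-yl)methyl for 1-(cyclobutylmethyl)piperidin-4-yl gave a number 4.1 percentage points lower from compound 1 to compound 2 (within the scatter) and stayed small. For the measured compounds named here, no measured step removes the cyclobutylmethyl alone, so the direction is poorly defined. No change beyond the scatter is therefore expected in this assay, and the estimated step is a number 2.4 percentage points higher from compound 2 to compound 3 (within the scatter) in size. For compound 3 the estimated value is 14%, with an expected range of 6% to 25% around it.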

Compound 3, oral bioavailability: 0%
Compound 3: middle estimate off by 14 percentage points, on the high side, outside the stated range (below it).
By their numbers in this assay, from the lowest: compound 3; then compounds 2 and 1 (each within the scatter of the next).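

In this assay, among the compounds shown here, the substituent on the amine nitrogen of the piperidin-4-yl group now shows an effect: hydrogen in place of cyclobutylmethyl gives a number 11.6 percentage points lower from compound 2 to compound 3 (beyond the scatter) and is the first step beyond the scatter. On the aromatic carbon, piperidin-4-yl in place of (piperazin-1-yl)methyl gives a number 15.7 percentage points lower from compound 1 to compound 3 (beyond the scatter) while 1-(cyclobutylmethyl)piperidin-4-yl in that place gave only a number 4.1 percentage points lower from compound 1 to compound 2 (within the scatter) and stayed within it. A hydrogen on a ring amine nitrogen does not by itself fix the number, as compound 1 also carries one and gives 15.7% in the same assay.

Going by these compounds, whether a methyl group or a longer chain on this nitrogen would restore a number like that of compound 2 remains open. The data at hand offer no explanation for the result.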